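This account rests on a few compounds, and the source may have more. Where it says the series, first, only, none or still open, it means among the compounds named here.

Within the data shown here, compound 2 `N/C(=N\NC(=S)N1CCCC1)c1ccc(F)cn1` holds the higher of the two numbers known so far: in a functional assay on HeLa cells (Homo sapiens) for cytotoxicity, read by MTT assay, with a stated time of 72 h, tested at 10 uM (a higher number here means more inhibition of growth at the concentration tested, a lower number less inhibition of growth), compound 2 gives 72.7%. Compound 1 `N/C(=N\NC(=S)N1CCOCC1)c1ccccn1` differs from it in two places at once and in this assay gives 56.3%, a gap that lies beyond the usual scatter. Compound 3 `N/C(=N\NC(=S)N1CCOCC1)c1ccc(F)cn1` has not been measured; it carries morpholin-4-yl in place of pyrrolidin-1-yl on a thiocarbonyl carbon, the same group that compound 1 carries. Among the measured compounds shown here, no measured pair isolates this change on its own, so only a modest downward step is expected, a number 10.7 percentage points lower from compound 2 to compound 3 (beyond the scatter). Compound 3 is therefore estimated to give 62%, between 42% and 80%.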

Compound 3, percent growth inhibition at one concentration: 81.9%
Beside the measured number, compound 3's estimate is 19.9 percentage points below it, outside the stated range (above it).
By their numbers in this assay, from the lowest: compound 1; then compounds 2 and 3 (each within the scatter of the next).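

Putting morpholin-4-yl in place of pyrrolidin-1-yl on a thiocarbonyl carbon gives a number 9.2 percentage points higher from compound 2 to compound 3 (within the scatter) in this assay, so this swap alone cannot be told apart from repeat-to-repeat variation. Fluoro in place of hydrogen on an aromatic carbon gives a number 25.6 percentage points higher from compound 1 to compound 3 (beyond the scatter), the first single change here that clearly moves the number. Going by these compounds, whether other amines on the thiocarbonyl carbon, such as piperidin-1-yl or dimethylamino, would behave alike stays open, as does whether chloro or methoxy could take the place of fluoro and keep this gain. Nothing measured here offers an explanation for either step.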